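A few compounds are considered here, and "the series" means these few. Any claim that something is new, unique, unknown or untested is made for them only; others in the source may bear on it.

Working notes on the series. In a functional assay on L1210 cells (Mus musculus) for inhibition (on this read-out lower numbers stand for stronger inhibition and higher numbers for weaker inhibition), compound 1 `COC(=O)Nc1nc2cc(C(=O)OCC3CC3)ccc2[nH]1` gives 6900 nM, the highest of the three numbers in hand. Nearest to it is compound 3 `O=C(Nc1nc2cc(C(=O)OCC3CC3)ccc2[nH]1)OCC1CC1` at 2200 nM; furthest is compound 2 `CC(C)OC(=O)Nc1nc2cc(C(=O)OC(C)C)ccc2[nH]1` at 730 nM. Within the data shown here, the one single-point step measured, a 3.1-fold lower number from compound 1 to compound 3 (0.50 log units; beyond the scatter), runs in the direction of adding a ring where compound 1 carries hydrogen, and it lowers the number by a modest amount beyond the scatter.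

Compound 4 `CCOC(=O)c1ccc2[nH]c(NC(=O)OC)nc2c1` has not yet been measured in this assay. Its change from compound 1 is methyl in place of cyclopropyl on a saturated chain carbon bound to an oxygen next to a carbonyl group, read one bond further out as cyclopropylmethoxycarbonyl to ethoxycarbonyl. Among the measured compounds shown here, no measured step covers this change directly. What is known is that adding cyclopropyl lowered the number in the step to compound 3, and that compound 2, with isopropyl groups, sits lowest of all. Taking away the ring is therefore expected to raise the number rather than lower it, but only modestly, likely close to the edge of the scatter.

Compound 4 is expected to give 11000 nM, with a range from 4500 nM to 27000 nM. The expected step is a 1.6-fold higher number from compound 1 to compound 4 (0.20 log units; within the scatter).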

Compound 4, half-maximal inhibitory concentration: 2800 nM
Beside the measured number, compound 4's estimate is 3.9-fold (0.59 log units) above it; the whole stated range lies above it.
By their numbers in this assay, from the lowest: compound 2; then compounds 3 and 4 (each within the scatter of the next); then compound 1.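

In this assay, the cyclopropylmethoxycarbonyl of compound 1 is not required for a lower number: exchanging it for ethoxycarbonyl gives a 2.5-fold lower number from compound 1 to compound 4 (0.39 log units; beyond the scatter), so the ring can leave this place and the number still falls. Set beside a 3.1-fold lower number from compound 1 to compound 3 (0.50 log units; beyond the scatter), where a cyclopropyl enters in place of hydrogen on a different chain and the cyclopropylmethoxycarbonyl stays, this shows that a cyclopropyl entering and a cyclopropyl leaving can both lower the number, each at its own place, so the ring has no single direction of effect across these compounds. Nothing at hand bears on why the number moves this way.

Still open, from the compounds shown here alone, is how far this chain can be varied: whether methoxycarbonyl, a longer chain such as propoxycarbonyl, or the free carboxylic acid would behave like ethoxycarbonyl. Also open, going by these compounds, is what the isopropoxycarbonyl contributes on its own, since compound 2 differs from compound 1 in more than one place and its number cannot be assigned to either change.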